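Pyrrolidine to piperidine swap on two sulfonamide cores

The source may report more compounds than this note shows. Statements on the series, on what has been measured and on what is new or still open speak of the compounds shown alone.

Compound 1 `CN(c1ccccc1)S(=O)(=O)c1ccc2c(c1)sc(=O)n2CCN1CCCC1` and compound 2 `CN(c1ccccc1)S(=O)(=O)c1ccc2c(c1)sc(=O)n2CCN1CCCCC1` share one core; compound 3 `O=c1sc2cc(S(=O)(=O)Nc3cccc4ccccc34)ccc2n1CCN1CCCC1` and compound 4 `O=c1sc2cc(S(=O)(=O)Nc3cccc4ccccc34)ccc2n1CCN1CCCCC1` share another. The difference between the two cores is not broken down here. In an assay on HEK293 cells for displacement of a labelled ligand from 5-hydroxytryptamine receptor 6 (Homo sapiens), read by radioligand binding, with a stated time of 60 min, tested at 100 nM (on this read-out higher numbers stand for more inhibition at the one concentration tested (going by the name of the read-out) and lower numbers for less inhibition), compound 1 gives 10%. Compound 2 gives 0% in this assay. The change between them, (piperidin-1-yl in place of pyrrolidin-1-yl on a saturated chain carbon, two bonds along the chain from an aromatic nitrogen), made a number 10 percentage points lower from compound 1 to compound 2 (within the scatter). Compound 3 gives 0% in this assay, level with compound 2 at the digits reported and within the scatter of compound 1. The same change, (piperidin-1-yl in place of pyrrolidin-1-yl on a saturated chain carbon, two bonds along the chain from an aromatic nitrogen), leads to compound 4; the place reads the same word for word in both pairs. The earlier step stayed within the scatter, and compound 3 already sits at the bottom of the range seen, so a small step is expected here as well, estimated as a number 2 percentage points higher from compound 3 to compound 4 (within the scatter). The expected level of compound 4 in this assay is about 2%, estimated to fall between -8% and 14%.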

Compound 4, a percentage reported as inhibition, at one concentration (the size of the read-out at that concentration, not a potency): 3%
Estimate against measurement, compound 4: 1 percentage points below; measured number inside the range.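

In this assay, piperidin-1-yl in place of pyrrolidin-1-yl on the core of compound 3 gives a number 3 percentage points higher from compound 3 to compound 4 (within the scatter). Set beside the same change on the core of compound 1, the two steps cannot be told apart: the same change on two cores in this assay, a number 10 percentage points lower (within the scatter) from compound 1 to compound 2 and a number 3 percentage points higher (within the scatter) from compound 3 to compound 4, 13 percentage points apart, within the scatter of two such steps Neither step moves inhibition beyond the scatter at the one concentration tested, so the notes can record only that this change raises inhibition beyond the scatter on neither core; a fixed size or direction for the change from one core to another is not shown, and nothing here gives a potency.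

Still open, from the compounds shown here alone, is whether a morpholine or a dimethylamino group in place of the saturated ring on the chain, or a longer chain than 2-(piperidin-1-yl)ethyl, would give a different level of inhibition on either core. Also open, going by these compounds, is whether the change would give a readable step on a core that starts from clearly higher inhibition.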